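Chloro in Place of Methyl on the Outer Phenyl Ring

A few compounds are considered here, and "the series" means these few. Any claim that something is new, unique, unknown or untested is made for them only; others in the source may bear on it.

The compounds measured so far:
Compound 1 `Cc1ccccc1-n1cc(-c2ccccc2NS(=O)(=O)c2c[nH]c(=O)[nH]c2=O)nn1` gives 3210 nM in a functional assay on A549 cells (Homo sapiens) for antiproliferative activity, read by MTT assay, with a stated time of 24 h; a higher number here means a weaker inhibitor, a lower number a stronger inhibitor.
Compound 2 `Cc1ccc(-n2cc(-c3ccccc3NS(=O)(=O)c3c[nH]c(=O)[nH]c3=O)nn2)cc1` gives 2910 nM.
Compound 3 `O=c1[nH]cc(S(=O)(=O)Nc2ccccc2-c2cn(-c3ccc(F)cc3)nn2)c(=O)[nH]1` gives 6390 nM.

Compound 1 holds the second highest of these three numbers. Its nearest neighbour is compound 2, reached by a 1.1-fold lower number from compound 1 to compound 2 (0.04 log units; within the scatter); the furthest is compound 3, reached by a 2.0-fold higher number from compound 1 to compound 3 (0.30 log units; within the scatter). Neither step leaves the scatter of repeated measurements.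

Compound 4 `O=c1[nH]cc(S(=O)(=O)Nc2ccccc2-c2cn(-c3ccccc3Cl)nn2)c(=O)[nH]1` differs from compound 1 in one place: chloro in place of methyl on an aromatic carbon. For the measured compounds named here, no measured pair shows exactly this swap. The closest guide is a 2.2-fold higher number from compound 2 to compound 3 (0.34 log units; beyond the scatter), where a halogen also replaced a methyl on the same phenyl ring, though at a different position, and gave a modest weakening. The mixed change a 2.0-fold higher number from compound 1 to compound 3 (0.30 log units; within the scatter) points the same way but stays within the scatter. A small rise in the number, or none beyond the scatter, is therefore the expectation.

Compound 4 is estimated at 4500 nM, with a likely range from 2000 nM to 10000 nM, which would mean an expected step of a 1.4-fold higher number from compound 1 to compound 4 (0.15 log units; within the scatter).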

Compound 4, half-maximal inhibitory concentration: 2740 nM
Compound 4: the middle estimate sits 1.6-fold (0.22 log units) above what was measured; the measured number falls inside the stated range.
By their numbers in this assay, from the lowest: compounds 4, 2, 1 and 3 (each within the scatter of the next, the first and the last beyond it).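

In this assay, replacing methyl with chloro at this place, ortho to a large group, changes nothing that can be told apart from the scatter (a 1.2-fold lower number from compound 1 to compound 4 (0.07 log units; within the scatter)), and compound 4 also stays within the scatter of compound 2 (a 1.1-fold lower number from compound 2 to compound 4 (0.03 log units; within the scatter)). A halogen on this phenyl ring therefore need not raise the number, since the 2-chlorophenyl group of compound 4 is separated from the 4-fluorophenyl group of compound 3 by a modest step beyond the scatter (a 2.3-fold lower number from compound 3 to compound 4 (0.37 log units; beyond the scatter)). Nothing measured here explains this difference.

The compounds shown carry only methyl, chloro and fluoro on this ring, so the effect of a methoxy group, an amine or a carboxylic acid at this place remains open. As far as these compounds go, whether any such group would move the number well beyond the scatter also remains unknown.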